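Benzoyl in place of acetyl on a halogenated thiourea

The source may hold more compounds than are shown below. What is called first, only, known or untested is meant among the compounds shown, and "the series" means these compounds.

Measured compounds:
Compound 1, `CC(=O)NC(=S)Nc1ccc(Br)cc1`, 1640 nM in an assay for inhibition of epoxide hydrolase 1 (Homo sapiens), read by fluorescence, using microsomes; on this read-out higher numbers stand for weaker inhibition and lower numbers for stronger inhibition.
Compound 2, `O=C(NC(=S)Nc1ccc(Br)c2ccccc12)c1ccccc1`, 1880 nM in this assay.
Compound 3, `CC(=O)NC(=S)Nc1ccc(Cl)cc1`, 2210 nM in this assay.

Compound 3 gives the highest of the three numbers in this assay, yet its gaps to the other two are small: compound 2 sits a 1.3-fold higher number from compound 1 to compound 3 (0.13 log units; within the scatter) apart in the other direction only when compared through compound 1, and the step of a 1.3-fold higher number from compound 1 to compound 3 (0.13 log units; within the scatter) itself lies within the scatter. All three compounds therefore stand close together.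

Compound 4, `O=C(NC(=S)Nc1ccc(Cl)cc1)c1ccccc1`, has not yet been measured. It differs from compound 3 in one place: phenyl in place of methyl on a carbonyl carbon. Among the compounds with values here, no measured step covers this exact change. Within the data shown here, the only related comparison is between compound 1, which carries the acetyl group and gives 1640 nM, and compound 2, which carries the benzoyl group on a different aromatic core and gives 1880 nM; those two numbers lie close together.

On this basis no step beyond the scatter is expected, and the estimated step is a 1.1-fold lower number from compound 3 to compound 4 (0.02 log units; within the scatter). Compound 4 is expected to give about 2100 nM in this assay, within a range of 900 nM to 5000 nM.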

Compound 4, half-maximal inhibitory concentration: 1640 nM
Compound 4: middle estimate off by 1.3-fold (0.11 log units), on the high side, within the range that was stated.
By their numbers in this assay, from the lowest: compounds 1, 4, 2 and 3 (each within the scatter of the next).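

Phenyl in place of methyl on a carbonyl carbon can now be read directly on one core, where it gives a 1.3-fold lower number from compound 3 to compound 4 (0.13 log units; within the scatter) in this assay. Even though phenyl brings in an aromatic ring and more heavy atoms than methyl, the step stays within the scatter, so at this position, with chloro on the core, the larger group is accepted with no measurable loss or gain. No measured evidence bears on why the number holds here.

From the compounds shown here alone, whether other groups on this carbonyl carbon, such as a longer chain like butyl or an amine, would also be accepted remains open. Going by these compounds, compound 1 and compound 2 differ in more than one place, so whether the same change behaves alike with bromo on the shared core also stays unknown.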